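The source may report more compounds than this note shows. Statements on the series, on what has been measured and on what is new or still open speak of the compounds shown alone.

In a functional assay on HepG2 cells (Homo sapiens) for antiproliferative activity, read by spectrophotometry, with a stated time of 2 days (on this read-out higher numbers stand for weaker inhibition of growth and lower numbers for stronger inhibition of growth), compound 2 `CN(c1cccc2c1CN(c1nc(Nc3ccc(C(F)(F)F)cc3)ncc1C(F)(F)F)C2)S(C)(=O)=O` gives > 30000 nM, which is a limit of the assay and not a number. Compound 1 `Cc1cc(F)ccc1Nc1ncc(C(F)(F)F)c(N2Cc3cccc(N(C)S(C)(=O)=O)c3C2)n1`, with a different group at the same place, gives 16800 nM. Compound 3 `COc1cc(Nc2ncc(C(F)(F)F)c(N3Cc4cccc(N(C)S(C)(=O)=O)c4C3)n2)cc(OC)c1` carries 3,5-dimethoxyphenyl in place of 4-(trifluoromethyl)phenyl on a nitrogen on an aromatic ring. Going by the values given here, the one measured change at this place, an at least 1.7-fold higher number from compound 1 to compound 2 (0.25 log units; that floor lies within the scatter), has a floor within the scatter, so it offers only weak guidance. No step beyond the scatter is therefore expected, and the estimated change is an at least 1.5-fold lower number from compound 2 to compound 3 (0.17 log units; that floor lies within the scatter). Compound 3 is expected at 20000 nM, with an estimated range from 7000 nM to 45000 nM.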

Compound 3, concentration for 50% growth inhibition: 1800 nM
Estimate against measurement, compound 3: 11-fold (1.05 log units) above, outside the stated range (below it).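

Putting 3,5-dimethoxyphenyl on this nitrogen gives an at least 16-fold lower number from compound 2 to compound 3 (1.22 log units; beyond the scatter) and a 9.3-fold lower number from compound 1 to compound 3 (0.97 log units; beyond the scatter), so this position clearly affects growth inhibition, which the earlier step, with its floor within the scatter, could not show. The first of these steps is only a floor, since compound 2 reads as a limit of the assay and not a number: the limit of > 30000 nM in this assay, at which 1 of the 3 values shown sits.

Which feature of 3,5-dimethoxyphenyl matters stays open, as only three groups at this place are shown. How a phenyl with a single methoxy group, or a morpholine, would behave here is also unknown.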